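This account rests on a few compounds, and the source may have more. Where it says the series, first, only, none or still open, it means among the compounds named here.

Three compounds of the series have been run in an assay on HL-60 cells for inhibition of glutathione S-transferase P (Homo sapiens); a lower number here means a stronger inhibitor, a higher number a weaker inhibitor. Compound 1 `C=C(C)C(=O)c1ccc(OCc2nc(-c3ccccc3)no2)cc1C` gives 1970 nM in this assay, and compound 2 `C=C(C)C(=O)c1ccc(OCc2nc(-c3ccccc3)no2)c(C)c1C` gives 1800 nM. Going by the values given here, the one single-point comparison measured so far, a 1.1-fold lower number from compound 1 to compound 2 (0.04 log units; within the scatter), shows that adding a methyl on the shared core leaves the readout essentially where it was. Compound 3 `C=C(CC)C(=O)c1ccc(OCc2nc(-c3ccc(F)cc3)no2)c(Cl)c1Cl` gives 3900 nM in this assay, the highest of the three numbers; its gap to compound 1 is within the scatter, while its gap to compound 2 is just beyond it.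

Compound 4 `C=C(CC)C(=O)c1ccc(OCc2nc(-c3ccc(Cl)cc3)no2)c(Cl)c1Cl` has not yet been measured. It differs from compound 3 by chloro in place of fluoro on an aromatic carbon, that is, 4-fluorophenyl to 4-chlorophenyl, para to a large group. Among the compounds with values here, no measured step exchanges one halogen for another on that ring; the only step at hand concerns a different ring and a different kind of substitution and stayed within the scatter. With nothing pointing in either direction, the expected step for compound 4 is a 1.1-fold lower number from compound 3 to compound 4 (0.05 log units; within the scatter), which is to say none beyond the scatter. Compound 4 is therefore estimated at 3500 nM in this assay, with a range from 1500 nM to 8000 nM.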

Compound 4, half-maximal inhibitory concentration: 5400 nM
Compound 4: middle estimate off by 1.5-fold (0.19 log units), on the low side; the range from low to high includes it.
By their numbers in this assay, from the lowest: compounds 2, 1, 3 and 4 (each within the scatter of the next, the first and the last beyond it).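

Going by these compounds alone, the change from 4-fluorophenyl to 4-chlorophenyl, para to a large group, is the first halogen exchange at this position, and in this assay it gives a 1.4-fold higher number from compound 3 to compound 4 (0.14 log units; within the scatter). Fluoro and chloro therefore cannot be told apart here on the core of compound 3, so this position accepts either halogen without a reading beyond the scatter, although one pair on one core sets no trend for the series. Nothing measured on either halogen or on the compounds themselves bears on this result, so the data offer no explanation for it.

The compounds shown leave open what a group other than a halogen would do at this position, for example a methoxy group, an amine or a carboxylic acid, and whether any of these would move the number beyond the scatter. They also leave open whether the same exchange of fluoro for chloro would read alike on a different core, such as that of compound 1.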